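Three Inert Analogues and a Fourth Awaiting Measurement

The compounds below may be only part of what the source reports. "The series", "measured", "known", "first", "only" and "open" are said of these compounds alone.

Compound 1 `Cc1ccc(NCc2cn(-c3ccccc3)nc2-c2ccc(C)cc2)cc1` was tested in an ADME assay on MDBK cells (Bos taurus) for cytotoxicity, read by MTT assay, with a stated time of 72 h; a lower number here means that less compound is tolerated, a higher number that more compound is tolerated. In this assay compound 1 gives > 100000 nM, which is a limit of the assay rather than a number. Compound 2 `Cc1ccc(-c2nn(-c3ccccc3)cc2CNc2ccccc2)cc1` differs from compound 1 by hydrogen in place of methyl on an aromatic carbon. In this assay compound 2 gives > 100000 nM, again a limit. Compound 3 `Cc1ccc(-c2nn(-c3ccccc3)cc2CNc2ccc(Cl)cc2)cc1` differs from compound 1 by chloro in place of methyl on an aromatic carbon, and this is also how the core of compound 3 differs from the core of compound 1. In this assay compound 3 gives > 100000 nM, once more a limit. The resulting steps are a step that the two limits leave unreadable from compound 1 to compound 2, a step that the two limits leave unreadable from compound 1 to compound 3 and a step that the two limits leave unreadable from compound 2 to compound 3, none of which can be sized because of the limit of > 100000 nM in this assay, at which 3 of the 3 values shown sit.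

Compound 4 `Clc1ccc(NCc2cn(-c3ccccc3)nc2-c2ccccc2)cc1` has not yet been measured. It differs from compound 3 by hydrogen in place of methyl on an aromatic carbon, the same change that is made from compound 1 to compound 2, so the account rests on that pair. Since compound 1 gives > 100000 nM and compound 2 gives > 100000 nM, both limits, the change left no readable step there, and the same outcome is expected here. Compound 4 is therefore expected to give 150000 nM in this assay, with a likely range from 60000 nM to 400000 nM. The step this estimate implies, a step that the limit leaves unreadable from compound 3 to compound 4, is expected to be no more than the scatter of the method, and most likely the assay will again report only a limit for compound 4.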

Compound 4, half-maximal cytotoxic concentration: > 100000 nM
Compound 4: only a limit was reported; the forecaster's own chance of this, stated with the estimate: 85%; the middle value lies beyond the limit too.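

In this assay compound 4 gives > 100000 nM as well, which is a limit of the assay and not a number. Within the data shown here, no step between compound 3 and compound 4, or between compound 4 and any other compound, can be read, because all of them stop at the same limit: the limit of > 100000 nM in this assay, at which 4 of the 4 values shown sit. The compounds shown leave open whether the exchanges among methyl, hydrogen and chloro make any difference to the tolerated concentration.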